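Bromo for Chloro on a Glycosylated Oxadiazole Series

A few compounds are considered here, and "the series" means these few. Any claim that something is new, unique, unknown or untested is made for them only; others in the source may bear on it.

Three compounds bearing a 1,2,4-oxadiazole were measured in an ADME assay on HepG2 cells (Homo sapiens) for cytotoxicity, read by MTT assay, with a stated time of 48 h; a lower number here means that less compound is tolerated, a higher number that more compound is tolerated. Compound 1 `CC(=O)OC[C@H]1O[C@H](OC[C@H](Cn2cc(COc3ccc(-c4noc(NC5CCCCC5)n4)cc3)nn2)OC(C)=O)C=C[C@@H]1OC(C)=O` gives 99.5 ug/mL. Compound 2 `CC(=O)OC[C@H]1O[C@H](OC[C@@H](Cn2cc(CN(c3nc(-c4ccc(Cl)cc4)no3)C3CCCCC3)nn2)OC(C)=O)C=C[C@@H]1OC(C)=O` gives 46.9 ug/mL. Compound 3 `C#CCN(c1nc(-c2ccc(OC)cc2)no1)C1CCCCC1` gives 72.5 ug/mL. Compound 2 sits at the lower end of these three numbers; its value and that of compound 3 lie within the scatter of each other, while the value of compound 1 lies beyond the scatter above it.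

Compound 4 `CC(=O)OC[C@H]1O[C@H](OC[C@@H](Cn2cc(CN(c3nc(-c4ccc(Br)cc4)no3)C3CCCCC3)nn2)OC(C)=O)C=C[C@@H]1OC(C)=O` differs from compound 2 only in one place: bromo in place of chloro on an aromatic carbon. For the measured compounds named here, no step between two measured compounds in this set isolates such a change, so the expectation rests on the modest size of the exchange alone. Compound 4 is expected to sit close to compound 2, with the step of a 1.1-fold lower number from compound 2 to compound 4 (0.05 log units; within the scatter) in this assay expected to stay within the scatter, leaning if anything slightly toward a lower number. Compound 4 is therefore estimated at 42 ug/mL, with a range from 20 ug/mL to 85 ug/mL.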

Compound 4, half-maximal cytotoxic concentration: 47.6 ug/mL
For compound 4 the middle estimate is 1.1-fold (0.05 log units) below the measured one; the range from low to high includes it.
By their numbers in this assay, from the lowest: compounds 2, 4, 3 and 1 (each within the scatter of the next, the first and the last beyond it).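

For the compounds shown here, the pair gives the first comparison in this set that isolates a single change. In this assay, the exchange of 4-chlorophenyl to 4-bromophenyl gives a 1.0-fold higher number from compound 2 to compound 4 (0.01 log units; within the scatter), so the two halogens cannot be told apart at this position, on an aromatic carbon para to a large group, in this assay. No measured evidence shown here bears on this result.

As far as these compounds go, whether the same position would give a similar reading with a smaller halogen such as fluoro, or with a different group such as an amine or a carboxylic acid, remains open. From the compounds shown here alone, compound 1 and compound 3 differ from this pair in more than one place, so the effect of changing the cyclohexyl group or the acetyl groups on their own also remains open.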